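A few compounds are considered here, and "the series" means these few. Any claim that something is new, unique, unknown or untested is made for them only; others in the source may bear on it.

Series notes. Compound 1 `O=C(O)c1cn(Cc2ccc(O)cc2)c2ccccc2c1=O` is the parent; in a functional assay, tested at 50 uM (a lower number here means a weaker effect, a higher number a stronger effect of the compound at the concentration tested), compound 1 gives 30.4%. Compound 2 `O=C(O)c1cn(Cc2ccc(O)c(O)c2)c2ccccc2c1=O` carries hydroxy in place of hydrogen on an aromatic carbon and in this assay compound 2 gives 61.9%, a step of a number 31.5 percentage points higher from compound 1 to compound 2 (beyond the scatter). Compound 3 `O=C(NO)c1cn(Cc2ccc(O)cc2)c2ccccc2c1=O` differs from compound 1 by hydroxyamino in place of hydroxy on a carbonyl carbon; in this assay compound 3 gives 51.1%, a step of a number 20.7 percentage points higher from compound 1 to compound 3 (beyond the scatter).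

Compound 4 `O=C(NO)c1cn(Cc2ccc(O)c(O)c2)c2ccccc2c1=O` is not yet measured. It differs from compound 3 by hydroxy in place of hydrogen on an aromatic carbon, the same change as that from compound 1 to compound 2, made here on the core of compound 3. The place of the change is described in the same words in both pairs, so the change is taken as the same. The two cores differ by hydroxyamino in place of hydroxy on a carbonyl carbon.

Expected: a step from compound 3 to compound 4 of a number 24.9 percentage points higher from compound 3 to compound 4 (beyond the scatter) in this assay, somewhat smaller than the earlier one, because a number 31.5 percentage points higher from compound 1 to compound 2 (beyond the scatter) started from a lower value and the read-out cannot rise without bound. For compound 4 the estimate in this assay is 76%, within 60% to 90%.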

Compound 4, a percentage reported as activity, at one concentration (the size of the read-out at that concentration, not a potency): 65.1%
Estimate against measurement, compound 4: 10.9 percentage points above; low and high end bracket the measured number.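

In this assay, hydroxy in place of hydrogen on an aromatic carbon (4-hydroxyphenyl to 3,4-dihydroxyphenyl) keeps its direction on the core of compound 3, with a step of a number 14 percentage points higher from compound 3 to compound 4 (beyond the scatter), but its size does not carry over from the core of compound 1: the same change on two cores in this assay, a number 31.5 percentage points higher (beyond the scatter) from compound 1 to compound 2 and a number 14 percentage points higher (beyond the scatter) from compound 3 to compound 4, 17.5 percentage points apart, beyond the scatter of two such steps

The change from hydroxy to hydroxyamino on the carbonyl carbon does not carry over either, since on the core of compound 2 it gives a step of a number 3.2 percentage points higher from compound 2 to compound 4 (within the scatter): the same change on two cores in this assay, a number 20.7 percentage points higher (beyond the scatter) from compound 1 to compound 3 and a number 3.2 percentage points higher (within the scatter) from compound 2 to compound 4, 17.5 percentage points apart, beyond the scatter of two such steps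

Within these four compounds the two changes therefore do not simply add, but the data do not show why, and a read-out at one concentration says nothing about potency.

Open, going by these compounds, is what a methoxy group or an amine would give in place of the added hydroxy, and what a primary amide or a methyl ester would give in place of the carboxylic acid. Also open, on these data alone, is whether the same non-additive pattern would appear on other cores or at other concentrations.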